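Nitrophenyl variant of compound 2 on the shared core

The source may hold more compounds than are shown below. What is called first, only, known or untested is meant among the compounds shown, and "the series" means these compounds.

Measured in an assay on isolated protein for inhibition of Apoptosis regulator Bcl-2 (Homo sapiens), read by fluorescence polarization; on this read-out lower numbers stand for stronger inhibition and higher numbers for weaker inhibition:
- compound 1 `O=C(O)c1ccc(COc2cccc(/C=C3\SC(=S)N(c4ccccc4)C3=O)c2)cc1` gives > 10000 nM, which is a limit of the assay.
- compound 2 `COc1ccccc1N1C(=O)/C(=C/c2cccc(OCc3ccc(C(=O)O)cc3)c2)SC1=S` gives 1600 nM.
- compound 3 `COc1ccccc1N1C(=O)/C(=C/c2ccc(OCC(=O)Nc3ccc(C(=O)O)cc3)cc2)SC1=S` gives 10000 nM.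

Compound 2 holds the lowest of the two numbers in this assay; compound 3 lies beyond the scatter above it, and compound 1 contributes only a limit.

Compound 4 `O=C(O)c1ccc(COc2cccc(/C=C3\SC(=S)N(c4ccc([N+](=O)[O-])cc4)C3=O)c2)cc1` differs from compound 2 by 4-nitrophenyl in place of 2-methoxyphenyl on an amide-type nitrogen in a ring. Among the compounds with values here, one measured step bears on this ring: an at least 6.2-fold lower number from compound 1 to compound 2 (0.79 log units; beyond the scatter), with compound 1 sitting at the limit described by the limit of > 10000 nM in this assay, at which 1 of the 3 values shown sits. That step shows the 2-methoxy group is worth at least a modest gain over the bare phenyl. Within the data shown here, compound 4 gives up that methoxy group, and no measured compound shows what 4-nitrophenyl contributes in its place. The gain from compound 1 to compound 2 is therefore not expected to carry over, and a step back toward the weaker side is expected: a 5.0-fold higher number from compound 2 to compound 4 (0.70 log units; beyond the scatter). Compound 4 is expected at 8000 nM, within 2000 nM to 30000 nM, with a sizeable chance that only a limit is reported.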

Compound 4, inhibition constant: > 10000 nM
Compound 4: only a limit was reported (the forecaster's own chance of this, stated with the estimate: 45%); middle value at least 1.2-fold (0.09 log units) from the limit.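

In this assay, 4-nitrophenyl in place of 2-methoxyphenyl on the amide-type nitrogen in the ring gives an at least 6.2-fold higher number from compound 2 to compound 4 (0.79 log units; beyond the scatter). Of the three groups shown on this nitrogen with the same side chain, only 2-methoxyphenyl gives a number short of the limit, so a substituent on this phenyl ring does not in itself hold the gain seen with the methoxy group. Compound 4 is reported only as a limit, as is compound 1, so the step between them cannot be read and nitro cannot be ranked against hydrogen here: the limit of > 10000 nM in this assay, at which 2 of the 4 values shown sit.

Open, from the compounds shown here alone, is how 4-methoxyphenyl or 2-nitrophenyl would fare on this nitrogen, which would separate the identity of the group from its place on the phenyl ring. Also open, going by these compounds, is whether a 2-ethoxyphenyl or 2-hydroxyphenyl group would keep or extend the gain.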